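The source may hold more compounds than are shown below. What is called first, only, known or untested is meant among the compounds shown, and "the series" means these compounds.

Compound 3 `C=C1CC[C@@H]2[C@](C)(CO[Si](C)(C)C(C)(C)C)[C@H](O)CC[C@@]2(C)[C@@H]1C/C=C1/C(=O)OC[C@H]1O` is the weakest of the three measured compounds: in a functional assay on P388 cells (Mus musculus) for cytotoxicity, read by sulforhodamine B assay (a lower number here means that less compound is needed, a higher number that more compound is needed for the effect), compound 3 gives 8.39 uM. Compound 2 `C=C1CC[C@@H]2[C@](C)(CO[Si](C)(C)C(C)(C)C)[C@H](O)CC[C@@]2(C)[C@@H]1C/C=C1/C(=O)OC[C@H]1OC(C)=O` differs from it by one change, (acetyl in place of hydrogen on an oxygen on a saturated carbon), and that change brings an 8.1-fold lower number from compound 3 to compound 2 (0.91 log units; beyond the scatter), so that compound 2 gives 1.03 uM. Compound 1 `C=C1CC[C@@H]2[C@](C)(CO[Si](c3ccccc3)(c3ccccc3)C(C)(C)C)[C@H](OC(C)=O)CC[C@@]2(C)[C@@H]1C/C=C1/C(=O)OC[C@H]1O` has a different core; the difference between the two cores is not broken down here. In this assay, among the compounds with values here, compound 1 gives 0.5 uM, the lowest number so far. Compound 4 `C=C1CC[C@@H]2[C@](C)(CO[Si](c3ccccc3)(c3ccccc3)C(C)(C)C)[C@H](OC(C)=O)CC[C@@]2(C)[C@@H]1C/C=C1/C(=O)OC[C@H]1OC(C)=O` is compound 1 carrying the same change, (acetyl in place of hydrogen on an oxygen on a saturated carbon), at the same place. Compound 1 already starts low at 0.5 uM, so a somewhat smaller gain than the earlier one is expected. Compound 4 is therefore expected to improve by a 3.3-fold lower number from compound 1 to compound 4 (0.52 log units; beyond the scatter). The estimate for compound 4 is 0.15 uM, most likely between 0.05 uM and 0.5 uM.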

Compound 4, concentration for half-maximal effect: 1.67 uM
For compound 4 the middle estimate is 11-fold (1.05 log units) below the measured one, outside the stated range (above it).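

On the core of compound 1, the acetyl group in place of hydrogen brings no gain in this assay, but instead a 3.3-fold higher number from compound 1 to compound 4 (0.52 log units; beyond the scatter) in this series. The same change therefore does not carry over from one core to the other, and its two steps run in opposite directions: the same change on two cores in this assay, an 8.1-fold lower number (0.91 log units; beyond the scatter) from compound 3 to compound 2 and a 3.3-fold higher number (0.52 log units; beyond the scatter) from compound 1 to compound 4, 27-fold (1.43 log units) apart, beyond the scatter of two such steps.

With a single pair on each core, this does not show which part of the core sets the direction, or what the change would do on a further core. Still open, as far as these compounds go, is whether a longer chain, such as butanoyl, in place of the acetyl would follow either step, and what an amine at that place would do.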